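The source may report more compounds than this note shows. Statements on the series, on what has been measured and on what is new or still open speak of the compounds shown alone.

In a functional assay on the whole organism with Mus musculus as the target (on this read-out higher numbers stand for an effect only at larger amounts of compound and lower numbers for an effect already at smaller amounts), compound 1 `Cc1c(C)c2c(c(C)c1N)CC(C)(C)O2` gives 7.8 mg/kg and compound 2 `CCNc1c(C)c(C)c2c(c1C)CC(C)(C)O2` gives 38.9 mg/kg. Compound 3 `Cc1c(C)c2c(c(C)c1NS(C)(=O)=O)CC(C)(C)O2` stands at > 100 mg/kg, which is a limit of the assay and not a number. Compound 4 `Cc1c(C)c2c(c(C)c1Nc1ccc(Cl)cc1)CC(C)(C)O2` differs from compound 3 by 4-chlorophenyl in place of methylsulfonyl on a nitrogen on an aromatic ring, with 4-chlorophenyl in place of methylsulfonyl on a nitrogen on an aromatic ring.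

Within the data shown here, three measured steps bear on this change: a 5.0-fold higher number from compound 1 to compound 2 (0.70 log units; beyond the scatter), an at least 12-fold higher number from compound 1 to compound 3 (1.10 log units; beyond the scatter) and an at least 2.5-fold higher number from compound 2 to compound 3 (0.41 log units; beyond the scatter). Both substituents raised the number, but methylsulfonyl raised it further, so replacing it should bring a modest or larger drop in this assay. No aryl group on this nitrogen has been measured, so the size remains uncertain. The expected change is an at least 3.3-fold lower number from compound 3 to compound 4 (0.52 log units; beyond the scatter). For compound 4, the estimated value is 30 mg/kg, with an expected range of 8 mg/kg to 100 mg/kg.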

Compound 4, dose for 50% inhibition: > 50 mg/kg
Compound 4 ended at the assay's limit; the forecaster's own chance of this, stated with the estimate: 25%; at least 1.6-fold (0.22 log units) between middle value and limit.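

Compound 4 in this assay ends at a limit and not at a number: the limit of > 50 mg/kg in this assay, at which 1 of the 4 values shown sits. An aryl group on this nitrogen also raises the number over the free amine, with an at least 6.4-fold higher number from compound 1 to compound 4 (0.80 log units; beyond the scatter) as the readable step. Against ethyl, an at least 1.2-fold higher number from compound 2 to compound 4 (0.10 log units; that floor lies within the scatter) has its floor within the scatter and sets no order, and the step against methylsulfonyl cannot be read, as both values are limits.

On these data alone, how far compound 4 lies past its limit stays open. So does whether a methyl or an acetyl group on this nitrogen would stay near compound 1.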